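The source may report more compounds than this note shows. Statements on the series, on what has been measured and on what is new or still open speak of the compounds shown alone.

Compound 1 `COc1cc(NC(C)CCCNC(=O)NCc2ccncc2)c2ncccc2c1` gives, in a functional assay on SW-620 cells (Homo sapiens), read by MTT assay, with a stated time of 72 h (a lower number here means a stronger inhibitor, a higher number a weaker inhibitor), a value of 2000 nM. Compound 3 `COc1cc(NC(C)CCCNC(=O)N(C2CCCCC2)C2CCCCC2)c2ncccc2c1` gives in this assay 15000 nM. Compound 2 `CCN(CC)C(=O)NCCCC(C)Nc1cc(OC)cc2cccnc12` reaches only a limit of the assay, > 100000 nM, so for compound 2 only a limit is known, and it sits at the limit of > 100000 nM in this assay, at which 1 of the 3 values shown sits. Among the compounds with values here, the one step that touches compound 2 is an at least 50-fold higher number from compound 1 to compound 2 (1.69 log units; beyond the scatter), a change of diethylamino in place of ((pyridin-4-yl)methyl)amino on a carbonyl carbon.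

Compound 4 `COc1cc(NC(C)CCCNC(=O)n2nnc3ccccc32)c2ncccc2c1` is not yet measured. It differs from compound 2 by a group of 9 heavy atoms (6 carbon, 3 nitrogen; one five-membered aromatic ring with 3 hetero atoms, one six-membered aromatic ring of carbon only) in place of a group of 5 heavy atoms (4 carbon, 1 nitrogen; no ring), on a carbonyl carbon. Within the data shown here, no measured step shows exactly this change; the step from compound 1 to compound 2 shows that removing a ring-bearing group on that carbonyl carbon was followed by a large rise, and compound 3, which carries two rings there, gives a number between those two. Compound 4 is therefore expected to come back down from the limit, with an estimated step of an at least 10-fold lower number from compound 2 to compound 4 (1.00 log units; beyond the scatter). For compound 4 the estimate in this assay is 10000 nM, with a range from 2000 nM to 100000 nM.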

Compound 4, half-maximal inhibitory concentration: > 100000 nM
Compound 4: no number, only a limit; the forecaster's own chance of this, stated with the estimate: 20%; at least 10-fold (1.00 log units) between middle value and limit.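

In this assay compound 4 gives only a limit, and it shares that limit with compound 2: the limit of > 100000 nM in this assay, at which 2 of the 4 values shown sit.

With the new group in place of ((pyridin-4-yl)methyl)amino on the carbonyl carbon, the result is an at least 50-fold higher number from compound 1 to compound 4 (1.69 log units; beyond the scatter), so a large loss at this position does not require the rings to be removed. Compounds 1 and 3 alone would fit a link between rings on the carbonyl carbon and a measurable value, but compound 4 goes against that link, and the step between its limit and that of compound 2 cannot be read.

The compounds shown leave open how far compound 2 and compound 4 lie past the limit. They also leave open whether morpholine or a plain phenylamino group on the carbonyl carbon would give a measurable value.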